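Tolerance of a methoxy-for-hydroxy exchange on the amide aryl

The compounds below may be only part of what the source reports. "The series", "measured", "known", "first", "only" and "open" are said of these compounds alone.

Measured compounds:
- compound 1, `COc1ccc(-c2cnc(NC(=O)c3ccc(O)cc3)n2C)cc1`: > 100000 nM
- compound 2, `Cn1c(-c2cccc([N+](=O)[O-])c2)cnc1NC(=O)c1ccc(F)cc1`: > 50000 nM
- compound 3, `COc1ccc(-c2cnc(NC(=O)c3ccc([N+](=O)[O-])cc3)n2C)cc1`: > 100000 nM

In a toxicity assay on THP-1 cells (Homo sapiens) for inhibition (a lower number here means that less compound is tolerated, a higher number that more compound is tolerated), compound 1 gives > 100000 nM, which is a limit of the assay and not a number. Compound 2 also sits at a limit, > 50000 nM. Compound 3 sits at a limit as well, > 100000 nM. Among the compounds with values here, the only step among measured compounds, a step that the two limits leave unreadable from compound 1 to compound 3, is unreadable, since both ends are limits; this rests on the limit of > 100000 nM in this assay, at which 2 of the 3 values shown sit, and (the limit of > 50000 nM in this assay, at which 1 of the 3 values shown sits).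

Compound 4, `COc1ccc(-c2cnc(NC(=O)c3ccccc3OC)n2C)cc1`, differs from compound 1 by 2-methoxyphenyl in place of 4-hydroxyphenyl on a carbonyl carbon. Within the data shown here, no measured step bears on this change, so compound 4 is expected to behave like compound 1 and to stay at or near the limit; the step of a number no higher from compound 1 to compound 4 (the limit leaves the size open) is expected to be none beyond the scatter. Compound 4 is therefore estimated at 100000 nM, in the range 30000 nM to 300000 nM.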

Compound 4, half-maximal cytotoxic concentration: > 100000 nM
Compound 4 ended at the assay's limit; the forecaster's own chance of this, stated with the estimate: 75%; the middle value lies on the limit itself.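

In this assay compound 4 gives > 100000 nM, a limit of the assay and not a number. Within the data shown here, compound 1 also sits at a limit, so no step from compound 1 to compound 4 can be read. The compounds shown leave open whether 2-methoxyphenyl in place of 4-hydroxyphenyl changes tolerance at all.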